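From Hydroxy to Phenyl on the Shared Core

This account rests on a few compounds, and the source may have more. Where it says the series, first, only, none or still open, it means among the compounds named here.

In a functional assay on Hs-578T cells (Homo sapiens) for inhibition, read by sulforhodamine B assay, with a stated time of 48 h (a higher number here means a weaker inhibitor of growth, a lower number a stronger inhibitor of growth), compound 1 `Cc1nnc(-c2nn(-c3ccccc3)c(-c3ccccc3)c2C#N)c2cn(-c3ccccc3)nc12` gives 1390 nM. In this assay compound 2 `N#Cc1c(-c2nnc(O)c3nn(-c4ccccc4)cc23)nn(-c2ccccc2)c1-c1ccccc1` gives 46800 nM. Compound 3 `N#Cc1c(-c2nnc(O)c3nn(-c4ccc(Cl)cc4)cc23)nn(-c2ccccc2)c1-c1ccccc1` gives > 100000 nM, which is a limit of the assay and not a number. Going by these compounds, it therefore stands at the limit of > 100000 nM in this assay, at which 1 of the 3 values shown sits, and its true position remains unknown.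

Compound 4 `N#Cc1c(-c2nnc(-c3ccccc3)c3nn(-c4ccc(Cl)cc4)cc23)nn(-c2ccccc2)c1-c1ccccc1` differs from compound 3 by phenyl in place of hydroxy on an aromatic carbon. Among the measured compounds shown here, two measured steps bear on this change. The closer guide is a 34-fold higher number from compound 1 to compound 2 (1.53 log units; beyond the scatter), where hydroxy in place of methyl on an aromatic carbon was the single difference. Read in reverse, that step suggests that removing the hydroxy could bring a large fall in the number, although phenyl itself has not been measured at this place. The second is an at least 2.1-fold higher number from compound 2 to compound 3 (0.32 log units; beyond the scatter), with chloro in place of hydrogen on an aromatic carbon. Compound 4 keeps that chloro, so a value near that of compound 1 is not assumed.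

A large step towards a lower number is expected in this assay. The expected change is an at least 20-fold lower number from compound 3 to compound 4 (1.30 log units; beyond the scatter). For compound 4 the estimated value is 5000 nM, with an expected range from 1000 nM to 30000 nM.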

Compound 4, concentration for 50% growth inhibition: 16800 nM
Compound 4: middle estimate off by 3.4-fold (0.53 log units), on the low side; measured number inside the range.
By their numbers in this assay, from the lowest: compound 1; then compound 4; then compound 2. At a limit, above all of these: compound 3.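

In this assay, with the chloro kept, putting phenyl in place of hydroxy on the aromatic carbon gives an at least 5.9-fold lower number from compound 3 to compound 4 (0.77 log units; beyond the scatter). Among the compounds shown here, this is the first measured step at this place in which an aromatic ring of carbon only enters, and it runs towards a lower number, as the step from hydroxy to methyl does when read in reverse. The place had so far been seen carrying only methyl and hydroxy, so the result shows that a phenyl there, in a compound that also keeps the chloro, still gives a measured number, while the size of the step stays open at one end, since compound 3 stands at a limit of the assay and not at a number: the limit of > 100000 nM in this assay, at which 1 of the 4 values shown sits.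

The compounds shown do not separate what the loss of hydroxy contributes from what the arrival of phenyl contributes, and they do not show how phenyl at this place reads without the chloro. Going by these compounds, how an amine, a methoxy group or a longer chain at this same place would compare with methyl and phenyl also stays open.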